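Fluoro added beside the ester on the aniline

The source may report more compounds than this note shows. Statements on the series, on what has been measured and on what is new or still open speak of the compounds shown alone.

Measured so far:
compound 1 `CCS(=O)(=O)Nc1cc(-c2ccc3ncnc(Nc4ccc(OC)c(Cl)c4)c3c2)cnc1OC` — 2810 nM
compound 2 `CCS(=O)(=O)Nc1cc(-c2ccc3ncnc(Nc4cccc(C(=O)OC)c4)c3c2)cnc1OC` — 2400 nM

In a functional assay on SK-HEP1 cells (Homo sapiens) for cytotoxicity, read by sulforhodamine B assay, with a stated time of 72 h (a higher number here means a weaker inhibitor, a lower number a stronger inhibitor), compound 2 sits at one end of the two numbers, yet a 1.2-fold lower number from compound 1 to compound 2 (0.07 log units; within the scatter) lies within the scatter, so the two are not separated. Compound 3 `CCS(=O)(=O)Nc1cc(-c2ccc3ncnc(Nc4ccc(F)c(C(=O)OC)c4)c3c2)cnc1OC` carries fluoro in place of hydrogen on an aromatic carbon. Within the data shown here, the single measured step exchanged the whole aniline and therefore does not bear on a fluoro added to an existing ring; no step of that kind is available. The expectation is accordingly no step beyond the scatter, no change at the digits printed from compound 2 to compound 3 (within the scatter). Compound 3 is estimated at 2400 nM, with a range of 1200 nM to 4800 nM.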

Compound 3, half-maximal inhibitory concentration: 5180 nM
Beside the measured number, compound 3's estimate is 2.2-fold (0.33 log units) below it; measured number above the stated range.
By their numbers in this assay, from the lowest: compounds 2, 1 and 3 (each within the scatter of the next, the first and the last beyond it).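

In this assay, among these compounds, the step of a 2.2-fold higher number from compound 2 to compound 3 (0.33 log units; beyond the scatter) is the first change confined to one atom on this aniline, and it shows that the ring carbon ortho to the methoxycarbonyl group and para to a large group does respond to substitution, if only modestly. The step of a 1.8-fold higher number from compound 1 to compound 3 (0.27 log units; within the scatter) leaves compound 3 unseparated from compound 1 despite the exchange of the whole aniline. Going by these compounds, whether a hydroxy or an amine at the fluoro position, or a carboxylic acid in place of the methoxycarbonyl group, would move the number remains open. Nothing shown accounts for the fluoro step.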